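The source may hold more compounds than are shown below. What is called first, only, known or untested is meant among the compounds shown, and "the series" means these compounds.

Measured so far in a functional assay on the whole organism (stomach) with Rattus norvegicus as the target; on this read-out lower numbers stand for an effect already at smaller amounts and higher numbers for an effect only at larger amounts of compound:
compound 1 `N#CNC(=N)NCCCCCn1nc(-c2ccccc2)ccc1=O` — a limit of the assay, > 100 mg/kg.
compound 2 `N#CNC(=N)NCCCCn1nc(-c2ccccc2)ccc1=O` — 77.2 mg/kg.
compound 3 `C/N=C(\S)NCCCn1nc(-c2ccccc2)ccc1=O` — a limit of the assay, > 100 mg/kg.

Compound 1 stands only at a limit in this assay, with no number behind it; (the limit of > 100 mg/kg in this assay, at which 2 of the 3 values shown sit). The chain-shortening step an at least 1.2-fold lower number from compound 1 to compound 2 (0.11 log units; that floor lies within the scatter) has a floor that lies within the scatter. The step that the two limits leave unreadable from compound 1 to compound 3 is unreadable, and an at least 1.2-fold higher number from compound 2 to compound 3 (0.11 log units; that floor lies within the scatter) again has a floor within the scatter.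

Compound 4 `CN(C)/C(=N/CCCCCn1nc(-c2ccccc2)ccc1=O)NC#N` differs from compound 1 by a group of 8 heavy atoms (4 carbon, 4 nitrogen; no ring) in place of a group of 6 heavy atoms (2 carbon, 4 nitrogen; no ring), on a saturated chain carbon, five bonds along the chain from an aromatic nitrogen. Within the data shown here, none of the measured steps touches this group: they alter chain length or exchange the whole terminal group, and none of them moves the read-out beyond the scatter. They bear on the step to compound 4 only by showing how little this series moves in this assay. The expected step is a step that the limit leaves unreadable from compound 1 to compound 4, that is, nothing beyond the scatter, and most likely once more only a limit. For compound 4 the estimate is 120 mg/kg, within 50 mg/kg to 300 mg/kg.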

Compound 4, dose for half-maximal effect: 81.5 mg/kg
Compound 4: the middle estimate sits 1.5-fold (0.17 log units) above what was measured, within the range that was stated.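

In this assay the new step reads an at least 1.2-fold lower number from compound 1 to compound 4 (0.08 log units; that floor lies within the scatter). This is the first change shown that keeps the chain and alters only the terminal group: at the place five bonds along the chain from an aromatic nitrogen, the group with 1 hydrogen-bond donor, in place of the one with 3 hydrogen-bond donors, gives a number for compound 4 of 81.5 mg/kg and no sign of a loss. The true size of this step stays unknown, as compound 1 is held at a limit and the step is only a floor: the limit of > 100 mg/kg in this assay, at which 2 of the 4 values shown sit.

Open, on these data alone, is whether this same group keeps a number on the chain of compound 2. Also open, as far as these compounds go, is whether a morpholine or a single ethyl in the entering group would move the read-out beyond the scatter from compound 4.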